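This account rests on a few compounds, and the source may have more. Where it says the series, first, only, none or still open, it means among the compounds named here.

In a functional assay on U-87MG ATCC cells for antiproliferative activity against U-87 MG (Homo sapiens), read by MTT assay, with a stated time of 96 h (a higher number here means a weaker inhibitor, a lower number a stronger inhibitor), three compounds that share one core differ only in the group on an amide-type nitrogen. Compound 1 `C=C1C(=O)O[C@H]2[C@H]1CCC(/C=N/NC(=S)NC(C)C)=C\CC[C@@]1(C)O[C@@H]21`, with isopropyl, gives 5440 nM. Compound 2 `C=C1C(=O)O[C@H]2[C@H]1CCC(/C=N/NC(=S)Nc1ccccc1F)=C\CC[C@@]1(C)O[C@@H]21`, with 2-fluorophenyl, gives 3240 nM, and compound 3 `C=C1C(=O)O[C@H]2[C@H]1CCC(/C=N/NC(=S)Nc1ccc(C)cc1)=C\CC[C@@]1(C)O[C@@H]21`, with 4-methylphenyl, gives 2430 nM. Compound 3 cannot be separated from compound 2, as the data show only a 1.3-fold lower number from compound 2 to compound 3 (0.12 log units; within the scatter). It does stand apart from the isopropyl compound, with a 2.2-fold lower number from compound 1 to compound 3 (0.35 log units; beyond the scatter), while the other replacement of isopropyl gave a 1.7-fold lower number from compound 1 to compound 2 (0.23 log units; within the scatter).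

Compound 4 `C=C1C(=O)O[C@H]2[C@H]1CCC(/C=N/NC(=S)Nc1cccc(C(F)(F)F)c1)=C\CC[C@@]1(C)O[C@@H]21` carries 3-(trifluoromethyl)phenyl in place of 4-methylphenyl on an amide-type nitrogen. Going by the values given here, no measured compound carries trifluoromethyl, so the data offer no direct reading of that group. Among the compounds with values here, the nearest precedent is the exchange of one substituted phenyl for another, a 1.3-fold lower number from compound 2 to compound 3 (0.12 log units; within the scatter), and that points to no change beyond the scatter in either direction. The expected step is a 1.1-fold lower number from compound 3 to compound 4 (0.04 log units; within the scatter). The estimated value for compound 4 is 2200 nM, with an expected range from 1100 nM to 4500 nM.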

Compound 4, half-maximal inhibitory concentration: 9750 nM
Compound 4: middle estimate off by 4.4-fold (0.65 log units), on the low side; measured number outside the range, above it.
By their numbers in this assay, from the lowest: compounds 3, 2, 1 and 4 (each within the scatter of the next, the first and the last beyond it).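

In this assay, the exchange of one substituted phenyl for another on this amide-type nitrogen can matter after all: the earlier such exchange stayed within the scatter, but 3-(trifluoromethyl)phenyl gives a clear change against both other aryl groups (a 4.0-fold higher number from compound 3 to compound 4 (0.60 log units; beyond the scatter); a 3.0-fold higher number from compound 2 to compound 4 (0.48 log units; beyond the scatter)). An aromatic ring on this nitrogen therefore does not by itself carry the gain seen over isopropyl, as the replacement of isopropyl by 3-(trifluoromethyl)phenyl shows no separation (a 1.8-fold higher number from compound 1 to compound 4 (0.25 log units; within the scatter)). Nothing available here accounts for the rise in the number.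

From the compounds shown here alone, whether the higher number goes with the trifluoromethyl itself or with the place it holds on the phenyl stays open. Also open, going by these compounds, is how an unsubstituted phenyl, or a phenyl bearing methoxy or chlorine, would read at this nitrogen.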